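Methyl on the aromatic carbon across two cores

The source may hold more compounds than are shown below. What is called first, only, known or untested is meant among the compounds shown, and "the series" means these compounds.

Of the compounds shown here, three have been measured in a functional assay on A-375 cells (Homo sapiens) for cytotoxicity, read by MTT assay, with a stated time of 72 h, tested at 100 uM; a higher number here means more inhibition of growth at the concentration tested, a lower number less inhibition of growth. Compound 1 `N/C(=N\NC(=S)N1CCCCCC1)c1ccccn1` gives 89% in this assay. Compound 2 `N/C(=N\NC(=S)N1CCOCC1)c1ccccn1` gives 14% in this assay, a value that lies well below compound 1. Compound 3 `Cc1cccc(/C(N)=N/NC(=S)N2CCOCC2)n1` gives 83.8% in this assay, which sits within the scatter of compound 1. How the core of compound 1 differs from the core of compound 2 is not broken down here.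

Compound 3 is made from compound 2 by one change, (methyl in place of hydrogen on an aromatic carbon). For the measured compounds named here, this change produced a number 69.8 percentage points higher from compound 2 to compound 3 (beyond the scatter), the only step in the set that is followed by a measurement.

Compound 4 `Cc1cccc(/C(N)=N/NC(=S)N2CCCCCC2)n1` is not yet measured. It is made from compound 1 by methyl in place of hydrogen on an aromatic carbon. The place of the change is given in the same words for both pairs, so this is the same change applied to the other core. Whether the change carries the same weight on the core of compound 1 cannot be judged from one step. Compound 1 already stands near full inhibition with 89%, which leaves little room upward, so the step from compound 1 to compound 4 is expected to be small, a number 1 percentage points higher from compound 1 to compound 4 (within the scatter), rather than anything like the step seen between compound 2 and compound 3. Compound 4 is accordingly estimated at 90% in this assay, with a range from 75% to 98%.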

Compound 4, percent growth inhibition at one concentration: 80.9%
Compound 4: the middle estimate sits 9.1 percentage points above what was measured; the measured number falls inside the stated range.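

In this assay, methyl in place of hydrogen on an aromatic carbon does not carry the same weight on the two cores: the same change on two cores in this assay, a number 69.8 percentage points higher (beyond the scatter) from compound 2 to compound 3 and a number 8.1 percentage points lower (within the scatter) from compound 1 to compound 4, 77.9 percentage points apart, beyond the scatter of two such steps

On the core of compound 1, the change gives a number 8.1 percentage points lower from compound 1 to compound 4 (within the scatter), so the large step seen on the core of compound 2 cannot be taken as a general result of adding this methyl in the series. For the compounds shown here, only two pairs are available, and all the readings come from one concentration, so they show that the size of the step can depend on the core, but not why it does, nor whether compound 1 and compound 4 would separate at a lower concentration.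

Still open, from the compounds shown here alone, is whether a longer chain such as ethyl, or a group such as an amine or a carboxylic acid, placed where the methyl sits, would also give steps that differ between the two cores. Also open, going by these compounds, is whether a third core would follow the pattern of compound 2 and compound 3 or that of compound 1 and compound 4 when the same methyl is added.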